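The compounds below may be only part of what the source reports. "The series", "measured", "known", "first", "only" and "open" are said of these compounds alone.

Measured in a functional assay on K562 cells (Homo sapiens) for cytotoxicity, read by trypan blue exclusion, with a stated time of 96 h; a higher number here means a weaker inhibitor, a lower number a stronger inhibitor:
- Compound 1 `COC(=O)CCNc1cc(CS(=O)(=O)/C=C/c2c(OC)cc(OC)cc2OC)ccc1OC`: 1000 nM
- Compound 2 `COc1cc(OC)c(/C=C/S(=O)(=O)Cc2ccc(OC)c(NC(F)(F)C(=O)O)c2)c(OC)c1`: 150 nM

Compound 2 has the lower of the two numbers, which makes it the stronger inhibitor of this pair, and its gap to compound 1 lies beyond the usual scatter. The next compound, compound 3 `COc1cc(OC)c(/C=C/S(=O)(=O)Cc2ccc(OC)c(NC(C(=O)O)c3ccc(Cl)cc3)c2)c(OC)c1`, keeps the shared core and differs at one place: carboxy(4-chlorophenyl)methyl in place of carboxy(difluoro)methyl on a nitrogen on an aromatic ring.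

One measured step changed a group at that same place: a 6.7-fold lower number from compound 1 to compound 2 (0.82 log units; beyond the scatter). It shows that this assay can respond to a change on this nitrogen, but it was a different change. For the measured compounds named here, no measured compound carries an aromatic ring in this group, so the direction remains uncertain. A step no larger than the measured one is expected, leaning slightly towards a higher number. The expected step is a 1.7-fold higher number from compound 2 to compound 3 (0.22 log units; within the scatter). For compound 3 the estimated value is 250 nM, with an expected range from 60 nM to 1000 nM.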

Compound 3, half-maximal inhibitory concentration: 250 nM
The estimate for compound 3 equals the measured number at the digits printed; the measured number falls inside the stated range.
By their numbers in this assay, from the lowest: compounds 2 and 3 (each within the scatter of the next); then compound 1.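

In this assay, this nitrogen accepts a group with 11 heavy atoms and one six-membered aromatic ring in place of one with 6 heavy atoms and no ring: carboxy(4-chlorophenyl)methyl for carboxy(difluoro)methyl gives a 1.7-fold higher number from compound 2 to compound 3 (0.22 log units; within the scatter), so the two cannot be told apart here. Replacing 2-(methoxycarbonyl)ethyl with this ring-bearing group also gives a 4.0-fold lower number from compound 1 to compound 3 (0.60 log units; beyond the scatter), so two different groups with a carboxy unit now stand on the favourable side of the ester-bearing group, though three compounds are too few to establish a general pattern. Nothing available explains why these groups give the numbers they do.

On these data alone, it remains open whether the 4-chloro substituent contributes anything, which a plain phenyl ring in its place would test, and whether a larger ring such as naphthyl would still be accepted at this nitrogen. As far as these compounds go, it also remains open whether the carboxylic acid itself is needed, which a primary amide or a tetrazole at that spot on the same group would help to settle.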